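Swapping an isopropyl for an isopropoxyethyl chain

A few compounds are considered here, and "the series" means these few. Any claim that something is new, unique, unknown or untested is made for them only; others in the source may bear on it.

Compound 1 `Nc1nc(Cl)c(-c2ccco2)c(N[C@@H]2C[C@H](CO)[C@@H](O)[C@H]2O)n1`: in an ADME assay on cells (Homo sapiens) for cytotoxicity, read by polymerase chain reaction, with a stated time of 3 days (on this read-out higher numbers stand for lower toxicity in this test and lower numbers for higher toxicity in this test), compound 1 sits at the limit of > 25000 nM, a limit of the test rather than a number.
Compound 2 `Cc1nc(NC(C)C)nc(N[C@@H]2C[C@H](CO)[C@@H](O)[C@H]2O)c1-c1nc2ccccc2s1`: in this assay compound 2 gives 13000 nM.

Of the compounds shown here, two have been measured, and only compound 2 returns a number; the other value is a limit (the limit of > 25000 nM in this assay, at which 1 of the 2 values shown sits). So compound 2 is the single fixed point on which any expectation must rest, and no step between two measured compounds is available to show how a change in structure moves the read-out.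

Compound 3 `Cc1nc(NCCOC(C)C)nc(N[C@@H]2C[C@H](CO)[C@@H](O)[C@H]2O)c1-c1nc2ccccc2s1` shares the core of compound 2 and differs in one place: 2-isopropoxyethyl in place of isopropyl on a nitrogen on an aromatic ring. The group that leaves and the group that enters are both small chains without a ring, and the rest of the molecule is unchanged.

With nothing measured on such a change, the expectation for the step from compound 2 to compound 3 is a small one, most likely none beyond the usual scatter, leaning if anything toward a higher number, and that estimate reads as a 1.2-fold higher number from compound 2 to compound 3 (0.09 log units; within the scatter). Compound 3 is therefore expected to give about 16000 nM in this assay, with a plausible range from 6000 nM to 40000 nM.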

Compound 3, half-maximal cytotoxic concentration: 8000 nM
Beside the measured number, compound 3's estimate is 2.0-fold (0.30 log units) above it, and the stated range covers the measured number.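

For the compounds shown here, this is the first step between two measured compounds in this assay, and 2-isopropoxyethyl in place of isopropyl on a nitrogen on an aromatic ring gives a 1.6-fold lower number from compound 2 to compound 3 (0.21 log units; within the scatter). The entering chain has 6 heavy atoms against 3 for the group that leaves, and it brings 1 hydrogen-bond acceptor, yet the read-out does not separate compound 2 from compound 3, so at this position the change from isopropylamino to (2-isopropoxyethyl)amino leaves no effect that can be told from repeat-to-repeat variation. No measurement shown here gives a reason for this step, and one step cannot supply one.

A single pair cannot show whether this nitrogen would stay as undemanding with a quite different group on it, such as a chain ending in an amine, a chain ending in a carboxylic acid, or a much longer alkyl chain. Going by these compounds alone, it also leaves open whether the same swap would read the same way on a different core, since only one pair of compounds sharing a core can be compared here.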